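This account rests on a few compounds, and the source may have more. Where it says the series, first, only, none or still open, it means among the compounds named here.

For the measured compounds named here, in a functional assay on A549 cells (Homo sapiens) for inhibition, read by sulforhodamine B assay, with a stated time of 48 h, tested at 50 uM (on this read-out lower numbers stand for less inhibition of growth and higher numbers for more inhibition of growth at the one concentration tested), compound 2 `COc1ccc([C@@H]2C/C(=N/OCc3cn(-c4ccc(Cl)cc4C)nn3)c3cc(CC=C(C)C)c(OC)cc3O2)cc1` gives 35%, the lower of the two numbers so far, and compound 1 `COc1ccc([C@@H]2C/C(=N/OCc3cn(-c4ccc(O)cc4)nn3)c3cc(CC=C(C)C)c(OC)cc3O2)cc1` gives 52%. Compound 3 `COc1ccc([C@@H]2C/C(=N/OCc3cn(-c4cccc(CO)c4)nn3)c3cc(CC=C(C)C)c(OC)cc3O2)cc1` carries 3-(hydroxymethyl)phenyl in place of 4-chloro-2-methylphenyl on an aromatic nitrogen. Going by the values given here, the only measured step at this place is a number 17 percentage points lower from compound 1 to compound 2 (beyond the scatter), where 4-chloro-2-methylphenyl replaced 4-hydroxyphenyl. Among the compounds with values here, that single modest step suggests that removing 4-chloro-2-methylphenyl may give a modest rise, though no measured compound carries 3-(hydroxymethyl)phenyl. The expected change is a number 11 percentage points higher from compound 2 to compound 3 (beyond the scatter). For compound 3 the estimated value is 46%, with an expected range of 31% to 61%.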

Compound 3, percent growth inhibition at one concentration: 43%
Compound 3: middle estimate off by 3 percentage points, on the high side; measured number inside the range.
By their numbers in this assay, from the lowest: compounds 2, 3 and 1 (each within the scatter of the next, the first and the last beyond it).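

In this assay, 3-(hydroxymethyl)phenyl on the aromatic nitrogen gives a number 8 percentage points higher from compound 2 to compound 3 (within the scatter) and a number 9 percentage points lower from compound 1 to compound 3 (within the scatter). Compound 3 therefore cannot be told apart from either compound 1 or compound 2, although those two remain separated by more than the scatter, so this position accepts a third aryl group without a clear shift. No available data explain these numbers. Open, from the compounds shown here alone, is whether an amine, a carboxylic acid or a longer hydroxyalkyl chain on the phenyl ring would move the number beyond the scatter.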